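The source may report more compounds than this note shows. Statements on the series, on what has been measured and on what is new or still open speak of the compounds shown alone.

Compounds measured so far in an ADME assay on a cell-free system (plasma) for protein binding; a lower number here means a smaller unbound share, a higher number a larger unbound share of the compound:
- compound 1, `CCOc1cc2nnc(C(N)=O)c(Nc3ccc(C)cc3F)c2cc1N1CCN(C)CC1`: compound 1 gives 0.016
- compound 2, `CCOc1cc2nnc(C(N)=O)c(Nc3cccc(Cl)c3F)c2cc1N1CCN(C)CC1`: compound 2 gives 0.019

Compound 2 holds the higher of the two numbers in this assay, with compound 1 nearest; the step of a 1.2-fold higher number from compound 1 to compound 2 (0.07 log units; within the scatter) lies within the scatter, so the two compounds are not told apart by this measurement. The next compound, compound 3, `CCOc1cc2nnc(C(N)=O)c(Nc3cccc(Cl)c3Cl)c2cc1N1CCN(C)CC1`, differs from compound 2 in one place: chloro in place of fluoro on an aromatic carbon. Going by the values given here, no measured step covers this exchange directly. Among the compounds with values here, the only step available, from the first compound to the second, swapped the whole aryl group on the amine nitrogen and moved the number by a 1.2-fold higher number from compound 1 to compound 2 (0.07 log units; within the scatter), which is within the scatter; it offers no sign that changes on that ring shift the unbound fraction much. The expectation for compound 3 is therefore a step of a 1.4-fold lower number from compound 2 to compound 3 (0.13 log units; within the scatter) from compound 2, a small move that is not expected to exceed the scatter. The estimate for compound 3 in this assay is 0.014, with a range from 0.007 to 0.028.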

Compound 3, unbound fraction: < 0.017
Compound 3 ended at the assay's limit; the forecaster's own chance of this, stated with the estimate: 5%; the middle value is on the limit's open side.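

In this assay compound 3 gives < 0.017, which is a limit of the assay and not a number. Chloro in place of fluoro on this aromatic carbon, ortho to a chloro group, gives an at least 1.1-fold lower number from compound 2 to compound 3 (0.04 log units; that floor lies within the scatter); this is only a floor on the step, so the true size of this exchange may be larger, while the step to the 2,3-dichlorophenyl group from the 2-fluoro-4-methylphenyl group cannot be read at all. The earlier compounds gave two readable numbers within the scatter of each other, whereas this single-atom exchange at this position is the first among those shown to take the read-out out of the readable range, and one compound now stands there: the limit of < 0.017 in this assay, at which 1 of the 3 values shown sits.

On these data alone, how far the unbound fraction of compound 3 lies past the limit stays unknown, and with it whether chloro in place of fluoro truly moves the number beyond the scatter. Also open, as far as these compounds go, is whether an amine, a hydroxyl or a carboxylic acid on this aromatic carbon would give a number that can be read in this assay.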